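Extending the side chain of compound 2 into an ester

The compounds below may be only part of what the source reports. "The series", "measured", "known", "first", "only" and "open" are said of these compounds alone.

Within the data shown here, compound 2, with the structure `CC(C)(C)[Si](C)(C)O[C@H]1CCCO[C@@H]1CC=O`, holds the lower of the two numbers measured so far in a functional assay on MCF7S cells (Homo sapiens); on this read-out lower numbers stand for stronger inhibition of growth and higher numbers for weaker inhibition of growth: compound 2 gives 21000 nM, whereas compound 1, `CC(C)(C)[Si](C)(C)O[C@H]1CCCO[C@@H]1CCO`, gives 55000 nM. Among the measured compounds shown here, the single recorded step connects these two: a 2.6-fold lower number from compound 1 to compound 2 (0.42 log units; beyond the scatter). Compound 3, `COC(=O)/C=C/C[C@H]1OCCC[C@@H]1O[Si](C)(C)C(C)(C)C`, has not yet been measured. It differs from compound 2 in one place: 2-(methoxycarbonyl)ethenyl in place of formyl on a saturated chain carbon bound to a saturated ring carbon. The measured step bears on this change only in that it touches the same chain carbon; there a hydroxymethyl became a formyl, whereas here the formyl grows into a longer chain carrying an ester. The ground for a prediction is therefore thin. Because a 2.6-fold lower number from compound 1 to compound 2 (0.42 log units; beyond the scatter) went toward stronger inhibition, a modest further lowering is expected for compound 3, though a result within the scatter, or a move the other way, cannot be ruled out. Compound 3 is estimated to give 12000 nM in this assay, with a range from 3000 nM to 50000 nM. The expected step is thus a 1.8-fold lower number from compound 2 to compound 3 (0.24 log units; within the scatter).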

Compound 3, concentration for 50% growth inhibition: 18000 nM
Compound 3: the middle estimate sits 1.5-fold (0.18 log units) below what was measured; the range from low to high includes it.
By their numbers in this assay, from the lowest: compounds 3 and 2 (each within the scatter of the next); then compound 1.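

In this assay, a 1.2-fold lower number from compound 2 to compound 3 (0.07 log units; within the scatter) shows that compound 2 and compound 3 cannot be told apart, so on this saturated chain carbon the much larger 2-(methoxycarbonyl)ethenyl group does as well as formyl, and the formyl itself is not required to keep this level of growth inhibition. Compared with the hydroxymethyl group, a 3.1-fold lower number from compound 1 to compound 3 (0.49 log units; beyond the scatter) is modest but beyond the scatter, so the two compounds with a carbonyl-bearing group, compound 2 and compound 3, both stand apart from compound 1, which has none. Nothing measured on these compounds explains the numbers, so the reason for this difference remains unknown.

The compounds shown leave open whether a carboxylic acid in place of the methyl ester, or an amide or an amine at the end of the chain, would move the number beyond the scatter. They also leave open whether the double bond matters, which a saturated chain of the same length carrying the same ester could test, and whether a still longer chain would be accepted at this place.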